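The source may hold more compounds than are shown below. What is called first, only, known or untested is meant among the compounds shown, and "the series" means these compounds.

The measured compounds:

Compound 1 `Cc1cccc(-c2noc([C@H](C)NC(=O)c3cc(C(F)(F)F)nn3C)n2)n1` gives > 30000 nM, a limit of the assay.
Compound 2 `C[C@H](NC(=O)c1cc(C(F)(F)F)nn1C)c1nc(-c2ccncc2)no1` gives 5250 nM.

In an assay on T-REx-293 cells for inhibition of potassium channel subfamily T member 1 (Homo sapiens), read by patch clamp (on this read-out higher numbers stand for weaker inhibition and lower numbers for stronger inhibition), compound 2 gives 5250 nM, the only number shown. Compound 1 sits at a limit, (the limit of > 30000 nM in this assay, at which 1 of the 2 values shown sits). Within the data shown here, the one measured step, an at least 5.7-fold lower number from compound 1 to compound 2 (0.75 log units; beyond the scatter), exchanged the whole ring hanging from the shared core. Compound 3 `COc1cc(-c2noc([C@H](C)NC(=O)c3cc(C(F)(F)F)nn3C)n2)ccn1` differs from compound 2 by methoxy in place of hydrogen on an aromatic carbon. Among the measured compounds shown here, no measured step adds a group to this ring while keeping it, so the measured step bears only loosely on the change; it shows that this ring matters, not how a methoxy on it acts. In this assay a step within the scatter, or at most a modest gain, is expected. Compound 3 is estimated at 3000 nM, between 800 nM and 12000 nM, which means an expected 1.8-fold lower number from compound 2 to compound 3 (0.24 log units; within the scatter).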

Compound 3, half-maximal inhibitory concentration: 27 nM
Compound 3: the middle estimate sits 110-fold (2.05 log units) above what was measured; measured number outside the range, below it.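

In this assay, a methoxy on an aromatic carbon next to the ring nitrogen, with everything else in the molecule kept, gives a 190-fold lower number from compound 2 to compound 3 (2.29 log units; beyond the scatter) and so far outweighs what the earlier ring exchange had shown. Among these compounds, that exchange showed only that the ring matters, whereas this result shows that one small group at one spot on the ring can change the reading greatly, and taken together the two changes amount to an at least 1100-fold lower number from compound 1 to compound 3 (3.04 log units; beyond the scatter) in this comparison. Compound 1 stands at a limit of the assay, not at a number: the limit of > 30000 nM in this assay, at which 1 of the 3 values shown sits.

On these data alone, whether an ethoxy, a hydroxyl, an amine or a chlorine on the same carbon would match the methoxy stays open, as does what a methoxy would do on another carbon of this ring. The compounds shown also do not tell why the methoxy has so large an effect.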